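From 2-hydroxyphenyl to 3-hydroxyphenyl in compound 4

The compounds below may be only part of what the source reports. "The series", "measured", "known", "first", "only" and "open" are said of these compounds alone.

Compound 1 (`O=C(NO)c1cccc(/C=C/c2ccnc(-c3cc(F)ccc3O)c2)c1`) gives 2710 nM in a functional assay on MGC-803 cells (Homo sapiens) for antiproliferative activity, read by CellTiter-Glo, with a stated time of 72 h (on this read-out higher numbers stand for weaker inhibition and lower numbers for stronger inhibition), while compound 2 (`O=C(NO)c1cccc(/C=C/c2ccnc(-c3ccccc3O)c2)c1`) gives 2810 nM and compound 3 (`O=C(NO)c1ccc(/C=C/c2ccnc(-c3ccccc3O)c2)cc1`) gives 1420 nM on the same scale. Compound 3 therefore stands within the scatter of both other compounds and cannot be ranked apart from them.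

Compound 4 (`O=C(NO)c1ccc(/C=C/c2ccnc(-c3cccc(O)c3)c2)cc1`) keeps the core of compound 3 and changes one group (3-hydroxyphenyl in place of 2-hydroxyphenyl on an aromatic carbon), with 3-hydroxyphenyl in place of 2-hydroxyphenyl on an aromatic carbon.

For the measured compounds named here, only one measured step differs in a single place (a 1.0-fold higher number from compound 1 to compound 2 (0.02 log units; within the scatter)). It puts hydrogen in place of fluoro and lies within the scatter. Going by the values given here, it bears only loosely on the present change, as no measured pair tests where the hydroxy group sits on the hydroxyphenyl group.

No shift beyond the scatter is therefore expected in either direction, and the estimated 1.1-fold higher number from compound 3 to compound 4 (0.05 log units; within the scatter) is small. In this assay the estimate for compound 4 is 1600 nM (expected range 550 nM to 4500 nM).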

Compound 4, half-maximal inhibitory concentration: 2100 nM
Beside the measured number, compound 4's estimate is 1.3-fold (0.12 log units) below it; low and high end bracket the measured number.
By their numbers in this assay, from the lowest: compounds 3, 4, 1 and 2 (each within the scatter of the next).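

Unlike the earlier step, this pair tests where the hydroxy group sits on the hydroxyphenyl group, and in this assay the change gives a 1.5-fold higher number from compound 3 to compound 4 (0.17 log units; within the scatter). This step lies within the scatter, so at this position, next to the ring nitrogen, 2-hydroxyphenyl and 3-hydroxyphenyl cannot be told apart on this read-out. No independent data accompany the result that could account for it or bear on it.

The compounds shown leave open whether the hydroxy group matters at this position at all, a question that an amine or a carboxylic acid in its place on the same aromatic ring, or an unsubstituted phenyl, would address. As far as these compounds go, whether 3-hydroxyphenyl in place of 2-hydroxyphenyl gives a similarly small step on the core of compound 2 also remains open.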